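From 4-chlorophenyl to 3-chlorophenyl on the shared core

A few compounds are considered here, and "the series" means these few. Any claim that something is new, unique, unknown or untested is made for them only; others in the source may bear on it.

In an ADME assay on cells (Peritoneal macrophage cell, Mus musculus) for cytotoxicity, read by fluorescence and resazurin assay, with a stated time of 3 days (on this read-out higher numbers stand for lower toxicity in this test and lower numbers for higher toxicity in this test), compound 3 `O=C(Nc1cc(-c2ccccn2)n[nH]1)N1CCC(c2ccc(Cl)cc2)CC1` gives > 55000 nM as a limit and not as a number. Compound 1 `N#Cc1ccc(C2CCN(C(=O)Nc3cc(-c4ccccn4)n[nH]3)CC2)cc1` likewise gives > 64000 nM as a limit. Compound 2 `N#Cc1ccc(OC2CCN(C(=O)Nc3cc(-c4ccccn4)n[nH]3)CC2)cc1` gives > 64000 nM as a limit too. Compound 3 therefore has no readable rank among the three, only its limit.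

The change leading to compound 4 `O=C(Nc1cc(-c2ccccn2)n[nH]1)N1CCC(c2cccc(Cl)c2)CC1` is 3-chlorophenyl in place of 4-chlorophenyl on a saturated ring carbon in which 3-chlorophenyl stands in place of 4-chlorophenyl on a saturated ring carbon, so the two have the same atoms, joined differently. Going by the values given here, three measured steps concern the same part of the molecule. There is a step that the two limits leave unreadable from compound 1 to compound 3 with chloro in place of cyano, there is a step that the two limits leave unreadable from compound 1 to compound 2 with 4-cyanophenoxy in place of 4-cyanophenyl, and there is a step that the two limits leave unreadable from compound 2 to compound 3 with 4-chlorophenyl in place of 4-cyanophenoxy. None of them has a readable size, and none relocates the chlorine, so they offer no measure for this change.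

With compound 3 at > 55000 nM as its limit, no step beyond the usual scatter is expected in this assay and no direction can be named. The expected step is a number no higher from compound 3 to compound 4 (the limit leaves the size open) and it rests on that limit alone. Compound 4 is itself expected to be reported most likely as a limit. Compound 4 is estimated at 55000 nM with an expected range from 25000 nM to 64000 nM in this test.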

Compound 4, half-maximal cytotoxic concentration: > 22000 nM
Compound 4: only a limit was reported; the forecaster's own chance of this, stated with the estimate: 70%; the middle value does not contradict the limit.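

In this assay, going by these compounds alone, compound 4 gives only a limit, as do compound 1, compound 2 and compound 3, so no step from any of these three to compound 4 can be read. The compounds shown leave open whether 3-chlorophenyl in place of 4-chlorophenyl changes the half-maximal cytotoxic concentration at all, and in which direction.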